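Series notes: chloro added to compound 3

A few compounds are considered here, and "the series" means these few. Any claim that something is new, unique, unknown or untested is made for them only; others in the source may bear on it.

In an assay for inhibition of HSP60/HSP10 (Homo sapiens), with a stated time of 60 min (a higher number here means a weaker inhibitor, a lower number a stronger inhibitor), compound 1 `O=C(Nc1ccc(Sc2nc3ccccc3s2)cc1)c1cc(Br)cc(Br)c1O` gives 4700 nM. Compound 2 `COc1ccc(Br)cc1C(=O)Nc1ccc(Sc2nc3ccccc3s2)cc1` reaches only a limit of this assay, > 100000 nM. Compound 3 `COc1c(Br)cc(Br)cc1C(=O)Nc1ccc(Sc2nc3ccccc3s2)cc1` likewise returns a limit, > 100000 nM. The steps of an at least 21-fold higher number from compound 1 to compound 2 (1.32 log units; beyond the scatter) and an at least 21-fold higher number from compound 1 to compound 3 (1.32 log units; beyond the scatter) both run out to that limit, while a step that the two limits leave unreadable from compound 2 to compound 3. Compound 3 therefore stands at the limit of > 100000 nM in this assay, at which 2 of the 3 values shown sit. Compound 4 `COc1c(Br)cc(Br)cc1C(=O)Nc1ccc(Sc2nc3ccccc3s2)c(Cl)c1` differs from compound 3 by chloro in place of hydrogen on an aromatic carbon. Among the compounds with values here, no measured step introduces a group at this place on the shared core, so none bears on the change directly; the only guide is that compound 3 already sits at the limit. Compound 4 is therefore expected to stay close to the limit, with a step that the limit leaves unreadable from compound 3 to compound 4 expected, and an estimated value of 150000 nM, ranging from 30000 nM to 1000000 nM.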

Compound 4, half-maximal inhibitory concentration: > 100000 nM
Compound 4: no number, only a limit; the forecaster's own chance of this, stated with the estimate: 85%; the middle value does not contradict the limit.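

In this assay, within the data shown here, compound 3 and compound 4 both return only limits, so no step between them can be read: the limit of > 100000 nM in this assay, at which 3 of the 4 values shown sit. Going by these compounds, whether chloro in place of hydrogen changes the number on a compound with a readable value stays open.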